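A few compounds are considered here, and "the series" means these few. Any claim that something is new, unique, unknown or untested is made for them only; others in the source may bear on it.

Compound 1, whose structure is `COc1cc(C(O)(C(F)(F)F)C(F)(F)F)cnc1N1CCN(S(=O)(=O)c2ccc(N)nc2)CC1`, has been tested in an ADME assay (liver) for metabolic stability, with Liver microsome (Homo sapiens) as the target, using microsomes and NADPH, with a stated time of 30 min, tested at 1 uM; a lower number here means slower removal, a higher number faster removal of the compound. In this assay compound 1 gives < 14 mL.min-1.g-1, which is a limit of the assay rather than a measured number. Compound 2, with the structure `Nc1ccc(S(=O)(=O)N2CCN(c3ncc(C(O)(C(F)(F)F)C(F)(F)F)cc3C#CCO)CC2)cn1`, differs from compound 1 by 3-hydroxyprop-1-yn-1-yl in place of methoxy on an aromatic carbon; in this assay compound 2 gives < 14 mL.min-1.g-1, again only a limit. Compound 3, with the structure `Nc1ccc(S(=O)(=O)N2CCN(c3ncc(C(O)(C(F)(F)F)C(F)(F)F)cc3-c3ccoc3)CC2)cn1`, carries furan-3-yl in place of methoxy on an aromatic carbon; in this assay compound 3 gives < 14 mL.min-1.g-1, likewise a limit. The steps a step that the two limits leave unreadable from compound 1 to compound 2, a step that the two limits leave unreadable from compound 1 to compound 3 and a step that the two limits leave unreadable from compound 2 to compound 3 therefore cannot be sized.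

Compound 4, with the structure `Nc1ccc(S(=O)(=O)N2CCN(c3ncc(C(O)(C(F)(F)F)C(F)(F)F)cc3-c3cccnc3)CC2)cn1`, differs from compound 1 as follows: pyridin-3-yl in place of methoxy on an aromatic carbon. Two replacements of the same methoxy by a ring or chain left the read-out at the limit, as summed up in the limit of < 14 mL.min-1.g-1 in this assay, at which 3 of the 3 values shown sit. Because of the limit of < 14 mL.min-1.g-1 in this assay, at which 3 of the 3 values shown sit, the step that the limit leaves unreadable from compound 1 to compound 4 is expected to stay hidden under the limit. Compound 4 is thus estimated to give 10 mL.min-1.g-1, within a range from 3 mL.min-1.g-1 to 25 mL.min-1.g-1.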

Compound 4, intrinsic clearance in microsomes: 17 mL.min-1.g-1
For compound 4 the middle estimate is 1.7-fold (0.23 log units) below the measured one, and the stated range covers the measured number.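

In this assay, among the compounds shown here, compound 4 gives the first reading at this position that is a number rather than a limit, so not every group placed here stays under that limit. The new steps are an at least 1.2-fold higher number from compound 1 to compound 4 (0.08 log units; that floor lies within the scatter), an at least 1.2-fold higher number from compound 3 to compound 4 (0.08 log units; that floor lies within the scatter) and an at least 1.2-fold higher number from compound 2 to compound 4 (0.08 log units; that floor lies within the scatter); each is only a floor and lies within the usual scatter, so even a real rise with pyridin-3-yl is not established, although the true steps may be larger. The steps among compound 1, compound 2 and compound 3 still cannot be read, and most of the series remains at one limit: the limit of < 14 mL.min-1.g-1 in this assay, at which 3 of the 4 values shown sit.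

On these data alone, it remains open whether a plain phenyl ring or an amine at this place would also give a number over the limit. As far as these compounds go, the true distance of compound 4 from the other three compounds also remains open.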